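The source may report more compounds than this note shows. Statements on the series, on what has been measured and on what is new or still open speak of the compounds shown alone.

For the measured compounds named here, compound 1 `COc1ccc(SCc2ccc(C(=O)Nc3ccccc3N)cc2)cc1` stands highest of the two compounds measured so far. In a functional assay on A549 cells (Homo sapiens) for inhibition, read by CCK-8 assay, with a stated time of 72 h, tested at 8 uM (a higher number here means more inhibition of growth at the concentration tested, a lower number less inhibition of growth), compound 1 gives 70.7%. Compound 2 `Nc1ccccc1NC(=O)/C=C/c1ccc(CSc2ccc(C(F)(F)F)cn2)cc1` gives 56.5% in this assay, a number lower than that of compound 1 by more than the usual scatter. Compound 3 `Nc1ccccc1NC(=O)c1ccc(CSc2ccc(F)cc2)cc1` is the next compound to be tested, and it differs from compound 1 in one place: fluoro in place of methoxy on an aromatic carbon. Going by the values given here, no pair of measured compounds isolates this exchange, so the expectation rests on compound 1 alone. The expected step is a number 5.7 percentage points lower from compound 1 to compound 3 (within the scatter), small and probably not beyond the scatter in either direction. Compound 3 is estimated to give 65% in this assay, within 50% to 80%.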

Compound 3, percent growth inhibition at one concentration: 44.5%
Compound 3: the middle estimate sits 20.5 percentage points above what was measured; measured number below the stated range.
By their numbers in this assay, from the lowest: compound 3; then compound 2; then compound 1.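

Exchanging methoxy for fluoro at this position, para to a large group, gives a clear change: in this assay there is a number 26.2 percentage points lower from compound 1 to compound 3 (beyond the scatter). This position on the ring therefore affects growth inhibition, and the loss of a single heavy atom from the substituent comes with a real difference. Nothing measured here explains the change.

Going by these compounds, whether an amine, a hydroxy group or a longer ether chain at this position would restore or further lower the inhibition remains open. The two compounds alone cannot show a trend across substituents.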